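The source may report more compounds than this note shows. Statements on the series, on what has been measured and on what is new or still open speak of the compounds shown alone.

Compound 1 `CCCN(CC1CC1)C(=O)c1sc(Nc2c(Cl)cc(Cl)cc2Cl)nc1C` gives 360 nM.
Compound 2 `CCN(CC)C(=O)c1sc(Nc2c(Cl)cc(Cl)cc2Cl)nc1C` gives 5000 nM.
Compound 3 `CCCN(CC1CC1)C(=O)c1sc(Nc2c(Cl)cc(Cl)cc2Cl)nc1CC` gives 11000 nM.

All three were tested in an assay for displacement of a labelled ligand from corticotropin-releasing factor receptor 1 (Homo sapiens); a higher number here means a weaker inhibitor, a lower number a stronger inhibitor. Compound 3 stands at the high end of the three numbers: compound 1 sits far below it, the change being a 31-fold higher number from compound 1 to compound 3 (1.49 log units; beyond the scatter), and compound 2 lies closest to it, with compound 2 giving 5000 nM against the value of compound 3 given above. The other measured step concerns the amide substituent, where a 14-fold higher number from compound 1 to compound 2 (1.14 log units; beyond the scatter) was seen.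

Compound 4 `CCCN(CC1CC1)C(=O)c1sc(Nc2c(Cl)cc(Cl)cc2Cl)nc1C(F)(F)F` differs from compound 3 in one place: trifluoromethyl in place of ethyl on an aromatic carbon. Going by the values given here, of the measured steps, only the one from compound 1 to compound 3 touches this part of the core, and it was large, a considerable loss on going from methyl to ethyl at that aromatic carbon. Among the compounds with values here, no measured pair shows what trifluoromethyl does at this place, so the direction of the step is not settled by the data. The account therefore expects compound 4 to stay in the weak region near compound 3, with the estimated step being a 1.8-fold lower number from compound 3 to compound 4 (0.26 log units; within the scatter). Compound 4 is expected to give about 6000 nM, within a range from 1200 nM to 30000 nM.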

Compound 4, inhibition constant: 31000 nM
Beside the measured number, compound 4's estimate is 5.2-fold (0.71 log units) below it, outside the stated range (above it).
By their numbers in this assay, from the lowest: compound 1; then compound 2; then compound 3; then compound 4.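

In this assay, trifluoromethyl recovers none of the loss seen with ethyl on this aromatic carbon: there is a 2.8-fold higher number from compound 3 to compound 4 (0.45 log units; beyond the scatter), and against the methyl of the core of compound 1 the change comes to an 86-fold higher number from compound 1 to compound 4 (1.94 log units; beyond the scatter). Ethyl and trifluoromethyl, two different replacements for methyl at this place, therefore both raise the number, and among compound 1, compound 3 and compound 4 methyl gives the lowest value, with no compound of the three going against this order. Nothing measured here accounts for trifluoromethyl giving a higher number than ethyl at this place.

From the compounds shown here alone, whether hydrogen, chlorine or an amine on this aromatic carbon would give a lower number than methyl remains open. Also open is whether the same order would hold with the diethylamino amide of compound 2, as every change at this place shown here carries the (cyclopropylmethyl)(propyl)amino group on the carbonyl.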